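The source may report more compounds than this note shows. Statements on the series, on what has been measured and on what is new or still open speak of the compounds shown alone.

Measured so far:
- Compound 1 `O=c1c(OC/C(=N/O)c2ccccc2)c(-c2ccccc2)oc2ccccc12`: 7210000 nM
- Compound 2 `O=c1c(OC/C(=N/O)c2ccc(F)cc2)c(-c2ccccc2)oc2ccccc12`: 6900000 nM
- Compound 3 `CO/N=C(/COc1ccc2oc(-c3ccccc3)cc(=O)c2c1)c1ccccc1`: 8200000 nM

All three were run in a functional assay on SK-HEP1 cells (Homo sapiens) for antiproliferative activity; on this read-out lower numbers stand for stronger inhibition of growth and higher numbers for weaker inhibition of growth. Compound 1 gives 7210000 nM there, and compound 2, with fluoro in place of hydrogen on an aromatic carbon, gives 6900000 nM; the step of a 1.0-fold lower number from compound 1 to compound 2 (0.02 log units; within the scatter) is within the scatter. Compound 3 gives 8200000 nM in this assay; its difference from compound 1 is not broken down here, and its values against compound 1 and compound 2 lie within the scatter of each other.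

Compound 4 `CO/N=C(/COc1ccc2oc(-c3ccccc3)cc(=O)c2c1)c1ccc(F)cc1` has not yet been measured. It carries fluoro in place of hydrogen on an aromatic carbon, the same change that separates compound 2 from compound 1, made on the core of compound 3. Since that earlier step was a 1.0-fold lower number from compound 1 to compound 2 (0.02 log units; within the scatter) and within the scatter, the step from compound 3 to compound 4 in this assay is expected to be of like size, a 1.0-fold lower number from compound 3 to compound 4 (0.01 log units; within the scatter). Compound 4 is therefore estimated at 8000000 nM in this assay, with 4000000 nM to 16000000 nM as the expected range.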

Compound 4, concentration for 50% growth inhibition: 7910000 nM
Compound 4: the middle estimate sits 1.0-fold (0.00 log units) above what was measured; low and high end bracket the measured number.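

In this assay, phenyl to 4-fluorophenyl gives a 1.0-fold lower number from compound 3 to compound 4 (0.02 log units; within the scatter), a step that stays within the scatter on this core. Set beside the same change on the other core, the two steps agree: the same change on two cores in this assay, a 1.0-fold lower number (0.02 log units; within the scatter) from compound 1 to compound 2 and a 1.0-fold lower number (0.02 log units; within the scatter) from compound 3 to compound 4, 1.0-fold (0.00 log units) apart, within the scatter of two such steps This shows that a change with no readable effect on the core of compound 1 also has no readable effect on the core of compound 3; it does not show that a change with a real effect would carry across these cores, and it rests on two pairs in a single assay.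

Open, from the compounds shown here alone, is whether a different group in the same place, such as an amine, a carboxylic acid or a longer alkyl chain, would move the number beyond the scatter on either core. Also open is how the free oxime and its methyl ether compare on one shared core, as the compounds shown carry each on a different core.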